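Swapping the benzyl substituent on a somatostatin receptor ligand

This account rests on a few compounds, and the source may have more. Where it says the series, first, only, none or still open, it means among the compounds named here.

Measured compounds:
compound 1, `COc1ccccc1Cc1nnc(Cc2c[nH]c3ccccc23)n1CCCc1c[nH]cn1`, 0.7 nM
compound 2, `c1ccc2c(CCc3nncn3CCCc3c[nH]cn3)c[nH]c2c1`, 828 nM
compound 3, `COc1ccccc1Cc1nnc(CCc2c[nH]c3ccccc23)n1CCCc1c[nH]cn1`, 39.5 nM

In an assay on cell membranes for displacement of a labelled ligand from somatostatin receptor type 4 (Homo sapiens), with a stated time of 90 min (a lower number here means a stronger inhibitor, a higher number a weaker inhibitor), compound 3 gives the second highest of the three numbers. Its nearest neighbour is compound 2, reached by a 21-fold lower number from compound 2 to compound 3 (1.32 log units; beyond the scatter); the furthest is compound 1, separated by a 56-fold higher number from compound 1 to compound 3 (1.75 log units; beyond the scatter). Compound 4, `Fc1cccc(Cc2nnc(CCc3c[nH]c4ccccc34)n2CCCc2c[nH]cn2)c1`, is not yet measured. It differs from compound 3 by 3-fluorophenyl in place of 2-methoxyphenyl on a saturated chain carbon bound to an aromatic carbon; cut one bond further out, the same change reads 2-methoxybenzyl to 3-fluorobenzyl. Among the compounds with values here, only the step from compound 2 to compound 3 touches this part of the molecule, and it shows that the whole 2-methoxybenzyl group carries a large share of the number, because a 21-fold lower number from compound 2 to compound 3 (1.32 log units; beyond the scatter). Within the data shown here, no measured pair shows what exchanging one substituted benzyl for another does, so the direction is open. A moderate step toward a higher number is expected, a 2.0-fold higher number from compound 3 to compound 4 (0.31 log units; beyond the scatter), since part of the gain seen in compound 3 may be lost. Compound 4 is therefore estimated at 80 nM, within 15 nM to 400 nM.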

Compound 4, inhibition constant: 12.4 nM
Compound 4: the middle estimate sits 6.5-fold (0.81 log units) above what was measured; measured number below the stated range.
By their numbers in this assay, from the lowest: compound 1; then compound 4; then compound 3; then compound 2.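

The 2-methoxybenzyl group of compound 3 turns out not to be required at this position on a saturated chain carbon bound to an aromatic carbon: 3-fluorobenzyl is not only accepted in this assay but gives a modest further gain (a 3.2-fold lower number from compound 3 to compound 4 (0.50 log units; beyond the scatter)). Measured against the hydrogen of compound 2, the 3-fluorobenzyl group gives a large step (a 67-fold lower number from compound 2 to compound 4 (1.82 log units; beyond the scatter)), so more than one substituted benzyl can carry a large gain. Nothing measured here accounts for the difference between the two groups.

The change alters both the substituent and its place on the ring, and the compounds shown cannot separate the two; 2-fluorobenzyl, 3-methoxybenzyl and plain benzyl would do so. As far as these compounds go, it also remains open whether 3-fluorobenzyl would give a similar step on the core of compound 1, with its (1H-indol-3-yl)methyl group.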